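A few compounds are considered here, and "the series" means these few. Any claim that something is new, unique, unknown or untested is made for them only; others in the source may bear on it.

Of the compounds shown here, three have been tested in an ADME assay on Vero cells (Chlorocebus sabaeus) for cytotoxicity, read by fluorescence and resazurin assay, with a stated time of 72 h (on this read-out higher numbers stand for weaker inhibition and lower numbers for stronger inhibition), and only one returns a number. Compound 1 `COc1ccc(CNC(=O)c2sc3c([N+](=O)[O-])cc(C(F)(F)F)cc3[n+]2[O-])cc1` gives 76000 nM. Compound 2 `CC(C)(C)OC(=O)N1CCC(Oc2ccc(Nc3ccc([N+](=O)[O-])cc3C#N)cc2)CC1` gives > 100000 nM, which is a limit of the assay and not a number. Compound 3 `C[C@H]1COC2(CCN(c3nc(=O)c4cc(C(F)(F)F)cc([N+](=O)[O-])c4s3)CC2)O1` gives > 100000 nM, which is also a limit. The picture so far is therefore set by the limit of > 100000 nM in this assay, at which 2 of the 3 values shown sit, and compound 2 has only that limit to its name.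

Compound 4 `N#Cc1cc([N+](=O)[O-])ccc1Nc1ccc(OC2CCNCC2)cc1` differs from compound 2 in one place, with hydrogen in place of tert-butoxycarbonyl on an amine nitrogen in a ring. Among the measured compounds shown here, no measured pair shows this change, so its size in this assay has to be estimated. A moderate move towards lower numbers, meaning stronger inhibition, is expected, though a reading at the same limit remains quite possible. For the measured compounds named here, a very large step is not expected, since the one number available, compound 1 at 76000 nM, is itself high, although its core is not the one shared by compound 2 and compound 4. The expected step is an at least 2.2-fold lower number from compound 2 to compound 4 (0.34 log units; beyond the scatter). For compound 4 the estimated value is 45000 nM, with an expected range of 12000 nM to 100000 nM.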

Compound 4, half-maximal inhibitory concentration: > 100000 nM
Compound 4 ended at the assay's limit; the forecaster's own chance of this, stated with the estimate: 40%; middle value at least 2.2-fold (0.34 log units) from the limit.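

Compound 2 and compound 4 both stand at a limit of the assay and not at a number, so no step can be read between them, because the comparison rests on limits alone: the limit of > 100000 nM in this assay, at which 3 of the 4 values shown sit.

The compounds shown leave open whether hydrogen in place of tert-butoxycarbonyl on an amine nitrogen in a ring changes the read-out in this assay at all, and by how much.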